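Acetylating the Free Hydroxyl of Compound 2

The source may hold more compounds than are shown below. What is called first, only, known or untested is meant among the compounds shown, and "the series" means these compounds.

Compound 2 `C=C1CC[C@@H]2[C@](C)(COC(C)=O)[C@H](O)CC[C@@]2(C)[C@@H]1C/C=C1/C(=O)OC[C@H]1O` was examined in a functional assay on P388 cells (Mus musculus) for cytotoxicity, read by sulforhodamine B assay (a lower number here means that less compound is needed, a higher number that more compound is needed for the effect), where compound 2 gives 2.04 uM. Its only companion, compound 1 `C=C1CC[C@@H]2[C@](C)(CO[Si](C)(C)C(C)(C)C)[C@H](O)CC[C@@]2(C)[C@@H]1C/C=C1/C(=O)OC[C@H]1OC(C)=O`, gives 1.03 uM in this assay; the two numbers lie within the usual scatter of each other, so no order can be read between them. Compound 3 `C=C1CC[C@@H]2[C@](C)(COC(C)=O)[C@H](O)CC[C@@]2(C)[C@@H]1C/C=C1/C(=O)OC[C@H]1OC(C)=O` carries acetyl in place of hydrogen on an oxygen on a saturated carbon, turning the hydroxy of compound 2 into an acetoxy. Going by the values given here, no measured pair isolates this change, so the expected step of a 1.5-fold lower number from compound 2 to compound 3 (0.16 log units; within the scatter) is small, likely not beyond the scatter. Compound 3 is estimated at 1.4 uM, with a range from 0.5 uM to 4 uM.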

Compound 3, concentration for half-maximal effect: 1.62 uM
Compound 3: middle estimate off by 1.2-fold (0.06 log units), on the low side; low and high end bracket the measured number.
By their numbers in this assay, from the lowest: compounds 1, 3 and 2 (each within the scatter of the next).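

In this assay acetyl in place of hydrogen on this oxygen gives a step that stays within the scatter (a 1.3-fold lower number from compound 2 to compound 3 (0.10 log units; within the scatter)), so hydroxy and acetoxy cannot be told apart here. Exchanging the silicon-bearing group for acetyl, on an oxygen on a saturated carbon, also stays within the scatter (a 1.6-fold higher number from compound 1 to compound 3 (0.20 log units; within the scatter)). No measurement at hand explains either step.

On these data alone, whether a longer chain such as butanoyl, or an amine-bearing acyl group, on this oxygen would shift the number beyond the scatter remains open.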